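Notes on the step from compound 1 to compound 4

The compounds below may be only part of what the source reports. "The series", "measured", "known", "first", "only" and "open" are said of these compounds alone.

Compound 1 `O=C(Nc1cccc(N2CCCC2=O)c1)C1CCCN(C(=O)c2cc(C(F)(F)F)cc(C(F)(F)F)c2)C1` gives 0% in an ADME assay on PC-3 cells (Homo sapiens) for cytotoxicity, read by WST assay, tested at 100 uM; a lower number here means less inhibition, a higher number more inhibition at the concentration tested (going by the name of the read-out). Compound 2 `Cc1cccc(C(=O)N2CCCC(C(=O)Nc3ccc(Cl)cc3)C2)c1` gives 0%, and compound 3 `CC(C)(C)CC(=O)Nc1cccc(C(=O)N2CCCC(C(=O)Nc3ccc(Cl)cc3)C2)c1` gives 0%; compound 1 thus stands level with both at the digits recorded, its nearest neighbour being compound 2 and its furthest compound 3, both within the scatter. Going by the values given here, the one single-point step available, no change at the digits printed from compound 2 to compound 3 (within the scatter), is a change on an aromatic carbon and shows no movement beyond the scatter.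

Compound 4 `O=C(Nc1cccc(OCCc2ccccn2)c1)C1CCCN(C(=O)c2cc(C(F)(F)F)cc(C(F)(F)F)c2)C1` differs from compound 1 by 2-(pyridin-2-yl)ethoxy in place of 2-oxopyrrolidin-1-yl on an aromatic carbon, the new group sitting on an aromatic carbon of a six-membered aromatic ring of carbon only, meta to a large group. Among the compounds with values here, no measured pair covers this exchange. Within the data shown here, the only evidence on changing an aromatic substituent is the step from compound 2 to compound 3, which was flat, and every measured compound sits at the same reading, so no step beyond the scatter is expected in this assay. The expected step of no change at the digits printed from compound 1 to compound 4 (within the scatter) is therefore essentially nil. Compound 4 is estimated at 0%, with a range from 0% to 15%.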

Compound 4, a percentage reported as inhibition, at one concentration (the size of the read-out at that concentration, not a potency): 5%
Compound 4: the middle estimate sits 5 percentage points below what was measured; low and high end bracket the measured number.
By their numbers in this assay, from the lowest: compounds 1, 2, 3 and 4 (each within the scatter of the next).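

In this assay, putting 2-(pyridin-2-yl)ethoxy in place of 2-oxopyrrolidin-1-yl gives a number 5 percentage points higher from compound 1 to compound 4 (within the scatter). Going by these compounds alone, this is the first reading for a change at this position, on an aromatic carbon meta to a large group, with the rest of the core of compound 1 held constant: a pyridine ring on an ethoxy chain replaces a non-aromatic lactam ring without a step beyond the scatter. No measured property is available to bear on this result.

On these data alone, it remains open whether a carboxylic acid or a dimethylamino group at this position would also stay within the scatter in this assay. As far as these compounds go, it is equally open whether a longer chain between the oxygen and the pyridine ring would leave the reading there.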